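This account rests on a few compounds, and the source may have more. Where it says the series, first, only, none or still open, it means among the compounds named here.

Compound 1, `COc1ccc(-c2nn(-c3ccccc3)cc2C(=O)NOCc2ccccc2)cc1`, is the reference point of this small set. In an ADME assay on HEK-293T cells (Homo sapiens) for antiproliferative activity, read by MTT assay, with a stated time of 48 h, in the presence of a further agent that is not named here (on this read-out higher numbers stand for lower toxicity in this test and lower numbers for higher toxicity in this test), compound 1 gives 201000 nM. Compound 2, `COc1ccc(-c2nn(-c3ccccc3)cc2C(=O)NOCc2ccccc2F)cc1`, differs from it by fluoro in place of hydrogen on an aromatic carbon, and in this assay compound 2 gives 24600 nM; the step is an 8.2-fold lower number from compound 1 to compound 2 (0.91 log units; beyond the scatter). Compound 3, `O=C(NOCc1ccccc1)c1cn(-c2ccccc2)nc1-c1ccc(F)cc1`, carries a different core, the difference from compound 1 being (fluoro in place of methoxy on an aromatic carbon); in this assay compound 3 gives 217000 nM, and the step is a 1.1-fold higher number from compound 1 to compound 3 (0.03 log units; within the scatter), so the two cores stand at much the same level in this test.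

Compound 4, `O=C(NOCc1ccccc1F)c1cn(-c2ccccc2)nc1-c1ccc(F)cc1`, has not yet been measured. It stands to compound 3 as compound 2 stands to compound 1: the difference is fluoro in place of hydrogen on an aromatic carbon, and its surroundings are described in the same words for both pairs, so it is the same change made on the other core. Among the compounds with values here, the only measured precedent for this change is an 8.2-fold lower number from compound 1 to compound 2 (0.91 log units; beyond the scatter). Since the two cores differ from one another within the scatter, as a 1.1-fold higher number from compound 1 to compound 3 (0.03 log units; within the scatter) shows, the expectation is that the change repeats itself to a similar degree, and the step from compound 3 to compound 4 is estimated at an 8.0-fold lower number from compound 3 to compound 4 (0.91 log units; beyond the scatter) because of an 8.2-fold lower number from compound 1 to compound 2 (0.91 log units; beyond the scatter). On that basis compound 4 is expected to give about 27000 nM in this assay, with a plausible range from 9000 nM to 90000 nM; a single precedent leaves that range wide.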

Compound 4, half-maximal cytotoxic concentration: 147000 nM
Beside the measured number, compound 4's estimate is 5.4-fold (0.74 log units) below it; the whole stated range lies below it.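

On the other core, benzyl to 2-fluorobenzyl gives a 1.5-fold lower number from compound 3 to compound 4 (0.17 log units; within the scatter), so in this assay the change does not carry over from the core of compound 1 with the size it had there, and the two steps differ: the same change on two cores in this assay, an 8.2-fold lower number (0.91 log units; beyond the scatter) from compound 1 to compound 2 and a 1.5-fold lower number (0.17 log units; within the scatter) from compound 3 to compound 4, 5.5-fold (0.74 log units) apart, beyond the scatter of two such steps Read the other way, fluoro in place of methoxy gives a 6.0-fold higher number from compound 2 to compound 4 (0.78 log units; beyond the scatter) among the 2-fluorobenzyl compounds, while among the benzyl compounds it gives no step beyond the scatter: the same change on two cores in this assay, a 1.1-fold higher number (0.03 log units; within the scatter) from compound 1 to compound 3 and a 6.0-fold higher number (0.78 log units; beyond the scatter) from compound 2 to compound 4, 5.5-fold (0.74 log units) apart, beyond the scatter of two such steps Both comparisons rest on the same four compounds and so describe a single mismatch, which shows that the two changes do not simply add up in this test, but it does not show why, nor which pair is the more typical of the series.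

The compounds shown leave open whether the larger step needs the methoxy group itself or would also appear with a hydroxy group, a methyl group or an amine in its place. They also leave open whether chloro or methyl in place of the fluoro on the benzyl group would follow compound 2 or compound 4 on either core.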